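The source may report more compounds than this note shows. Statements on the series, on what has been measured and on what is new or still open speak of the compounds shown alone.

Compound 1 `Cc1ccc(NC2=CC(=O)c3nc4n(c3C2=O)[C@H]2OC[C@@H](O)[C@H]2OC4)cc1C`: 2080 nM in a functional assay on MCF7 cells (Homo sapiens) for inhibition, read by sulforhodamine B assay; a higher number here means a weaker inhibitor, a lower number a stronger inhibitor.
Compound 2 `O=C1C(Nc2ccccc2)=CC(=O)c2c1nc1n2[C@H]2OC[C@@H](O)[C@H]2OC1`: > 4000 nM, a limit of the assay.
Compound 3 `O=C1C(NCc2ccccc2)=CC(=O)c2c1nc1n2[C@H]2OC[C@@H](O)[C@H]2OC1`: > 8000 nM, also a limit of the assay.

Within the data shown here, compound 1 stands as the only numbered value of the three; compounds 2 and 3 sit at limits, described by the limit of > 4000 nM in this assay, at which 1 of the 3 values shown sits, and (the limit of > 8000 nM in this assay, at which 1 of the 3 values shown sits). Among the measured compounds shown here, the single measured step, a step that the two limits leave unreadable from compound 2 to compound 3, has no readable size. Compound 4 `O=C1C=C(Nc2ccc(Br)cc2)C(=O)c2c1nc1n2[C@H]2OC[C@@H](O)[C@H]2OC1` differs from compound 1 by 4-bromophenyl in place of 3,4-dimethylphenyl on an amine nitrogen. For the measured compounds named here, no measured step covers a change of this kind; compounds 1 and 2 show only that one gives a number and the other a limit. Compound 4 is therefore expected to weaken modestly, an estimated step of a 1.7-fold higher number from compound 1 to compound 4 (0.23 log units; within the scatter), with an estimated value of 3500 nM, between 1400 nM and 9000 nM.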

Compound 4, half-maximal inhibitory concentration: 2580 nM
Estimate against measurement, compound 4: 1.4-fold (0.13 log units) above; measured number inside the range.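

Among these compounds, the first readable step at this amine nitrogen in this assay is a 1.2-fold higher number from compound 1 to compound 4 (0.09 log units; within the scatter), for 4-bromophenyl in place of 3,4-dimethylphenyl. This exchange therefore leaves the number unchanged within the scatter, which the earlier limits could not show. Nothing measured here bears on why these two groups read alike.

On these data alone, what stays open is whether the level holds with a carboxylic acid or an amine on the phenyl ring. A longer alkyl chain in place of the ring on this nitrogen is equally unresolved.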